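Methoxy in Place of Amino on a Weak Growth Inhibitor

The source may hold more compounds than are shown below. What is called first, only, known or untested is meant among the compounds shown, and "the series" means these compounds.

Compound 1 `Oc1cc(-c2ccccc2)nn1-c1ccc(F)cn1` gives 28900 nM in an ADME assay on WI-38 cells (Homo sapiens) for inhibition, read by CellTiter-Glo, with a stated time of 4 days; a lower number here means a stronger inhibitor of growth, a higher number a weaker inhibitor of growth. Compound 2 `Nc1ccc(-n2nc(-c3ccccc3)cc2O)nc1` appears in this assay only as a limit of the assay, > 30000 nM, not as a number. So compound 2 stands among the values shown without a single number of its own, as the limit of > 30000 nM in this assay, at which 1 of the 3 values shown sits, records. Within the data shown here, the step of an at least 1.0-fold higher number from compound 1 to compound 2 (0.01 log units; that floor lies within the scatter) is the only measured step here. Compound 3 `Cc1ccc(-n2nc(-c3ccccc3)cc2O)nc1` gives 26300 nM; > 12000 nM (2 entries) in this assay; the several entries of compound 3 in this assay, 26300 nM; > 12000 nM (2 entries) shows how its repeats spread. Compound 4 `COc1ccc(-n2nc(-c3ccccc3)cc2O)nc1` carries methoxy in place of amino on an aromatic carbon. Among the measured compounds shown here, no measured step covers a methoxy, and every value shown sits near the ceiling of the assay, so compound 4 is expected to stay weak, with a number no higher from compound 2 to compound 4 (the limit leaves the size open) as the expected step. Compound 4 is estimated at 30000 nM, between 15000 nM and 60000 nM.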

Compound 4, concentration for 50% growth inhibition: 25400 nM
The estimate for compound 4 lay 1.2-fold (0.07 log units) above the measured number, and the stated range covers the measured number.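

In this assay, methoxy on this aromatic carbon gives a measured number where amino gave only a limit, and the change reads as an at least 1.1-fold lower number from compound 2 to compound 4 (0.07 log units; that floor lies within the scatter). Set against fluoro at the same place, methoxy does not separate from it, with a 1.1-fold lower number from compound 1 to compound 4 (0.06 log units; within the scatter). The true size of the change from amino stays unfixed: the limit of > 30000 nM in this assay, at which 1 of the 4 values shown sits.

The compounds shown leave open whether a carboxylic acid or a longer chain such as butoxy at this place would move the number beyond the scatter. They also leave open whether any group here gives a clearly stronger inhibitor of growth.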